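This account rests on a few compounds, and the source may have more. Where it says the series, first, only, none or still open, it means among the compounds named here.

Among the measured compounds shown here, in a functional assay on HeLa cells (Homo sapiens) for cytotoxicity, read by MTT assay, with a stated time of 48 h (a higher number here means a weaker inhibitor, a lower number a stronger inhibitor), compound 1 `O=C(O)CN1C(=O)/C(=C/c2nc3ccccc3n2Cc2ccccc2F)SC1=S` gives 640 nM, the lower of the two numbers so far, while compound 2 `O=C(O)CN1C(=O)/C(=C/c2nc3ccccc3n2Cc2ccc(F)c(F)c2)SC1=S` gives 16000 nM. Compound 3 `COc1ccc2c(c1)nc(/C=C1\SC(=S)N(CC(=O)O)C1=O)n2Cc1ccccc1F` keeps the 2-fluorophenyl group of compound 1 and alters the core: methoxy in place of hydrogen on an aromatic carbon. For the measured compounds named here, the only measured step, a 25-fold higher number from compound 1 to compound 2 (1.40 log units; beyond the scatter), is large, but it swaps 2-fluorophenyl for 3,4-difluorophenyl elsewhere in the molecule, so it bears only indirectly and sets no direction here. A modest rise is expected, and the expected step is a 2.3-fold higher number from compound 1 to compound 3 (0.37 log units; beyond the scatter). Compound 3 is estimated at 1500 nM, within an expected range from 350 nM to 6000 nM.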

Compound 3, half-maximal inhibitory concentration: 22500 nM
Compound 3: the middle estimate sits 15-fold (1.18 log units) below what was measured; measured number outside the range, above it.
By their numbers in this assay, from the lowest: compound 1; then compounds 2 and 3 (each within the scatter of the next).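

In this assay, putting methoxy in place of hydrogen on the carbon-only aromatic ring of the fused system gives a 35-fold higher number from compound 1 to compound 3 (1.55 log units; beyond the scatter). The earlier step changed only the fluorophenyl group, whereas this one shows that a single small group on the core can also move the number strongly. Nothing available explains why this happens.

From the compounds shown here alone, whether an amine or a chlorine atom at this same place would raise the number as methoxy does remains open. So does the effect of methoxy elsewhere on that ring.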